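The compounds below may be only part of what the source reports. "The series", "measured", "known", "first", "only" and "open" are said of these compounds alone.

Measured compounds:
Compound 1 `C=CCOC(=O)SCCCCCCNC(=O)c1cc(-c2ccncc2)n[nH]1` gives 12600 nM.
Compound 2 `O=C(NCCCCCCS)c1cc(-c2cnccn2)n[nH]1` gives only the assay limit, > 50000 nM.
Compound 3 `O=C(NCCCCCCS)c1cc(-c2ccc(-c3ccccc3)cc2)n[nH]1` gives only the assay limit, > 50000 nM.

Among the compounds with values here, in a functional assay on MCF7 cells (Homo sapiens) for inhibition, read by MTT assay, with a stated time of 96 h (a higher number here means a weaker inhibitor of growth, a lower number a stronger inhibitor of growth), compound 1 gives 12600 nM, the only number among the three values shown. Compound 2 and compound 3 sit at the limit of > 50000 nM in this assay, at which 2 of the 3 values shown sit. Compound 4 `CCC(=O)SCCCCCCNC(=O)c1cc(-c2ccncc2)n[nH]1` is not yet measured. It differs from compound 1 by ethyl in place of allyloxy on a carbonyl carbon. Within the data shown here, no step between two measured compounds differing in one place is available, so the size of this step can only be expected, not read off. The carbamate-to-thioester exchange keeps the chain and the core of compound 1 intact, so the step of a 1.1-fold lower number from compound 1 to compound 4 (0.02 log units; within the scatter) is expected to stay within the scatter, in either direction. Compound 4 is estimated at 12000 nM, with a range from 5000 nM to 30000 nM.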

Compound 4, concentration for 50% growth inhibition: > 50000 nM
Compound 4 was reported as a limit (the forecaster's own chance of this, stated with the estimate: 10%); middle value at least 4.1-fold (0.61 log units) from the limit.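

In this assay, the exchange of allyloxy for ethyl on a carbonyl carbon, with chain and core unchanged, gives an at least 3.9-fold higher number from compound 1 to compound 4 (0.59 log units; beyond the scatter). This position is therefore not indifferent to the change, and the carbamate of compound 1 does better here than the thioester of compound 4. Compound 4 gives only a limit of the assay: the limit of > 50000 nM in this assay, at which 3 of the 4 values shown sit.

On these data alone, how far compound 4 lies past that limit stays open. So does whether ethoxy or butyl on the same carbonyl carbon would hold the activity of compound 1.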